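Swapping Phenyl for Pyridin-3-yl at the Alkyne

This account rests on a few compounds, and the source may have more. Where it says the series, first, only, none or still open, it means among the compounds named here.

Measured so far:
compound 1, `O=C(O)COc1ccc(Cl)cc1C#Cc1ccccc1`: 108 nM
compound 2, `COc1ccccc1C#Cc1cc(Cl)ccc1OCC(=O)O`: 190 nM

Both compounds were tested in an assay on CHO cells for displacement of a labelled ligand from prostaglandin D2 receptor 2 (Homo sapiens), read by scintillation counting; a higher number here means a weaker inhibitor, a lower number a stronger inhibitor. Compound 1 has the lowest of the two numbers, and its nearest neighbour is compound 2, separated by a 1.8-fold higher number from compound 1 to compound 2 (0.25 log units; within the scatter), a step that brings a methoxy in place of hydrogen on an aromatic carbon and stays within the scatter.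

Compound 3, `O=C(O)COc1ccc(Cl)cc1C#Cc1cccnc1`, is not yet measured. It differs from compound 1 in one place: pyridin-3-yl in place of phenyl on a triple-bonded carbon. Among the measured compounds shown here, no measured step involves a change of this kind; the single known step concerns a methoxy group and does not speak to a ring nitrogen at the alkyne. The expectation therefore rests on the shared core alone, and a step of modest size, more likely toward a higher number, is expected in this assay .

Compound 3 is expected to give about 200 nM, within 60 nM to 700 nM. The expected step is a 1.9-fold higher number from compound 1 to compound 3 (0.27 log units; within the scatter).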

Compound 3, inhibition constant: 117 nM
Compound 3: middle estimate off by 1.7-fold (0.23 log units), on the high side; low and high end bracket the measured number.
By their numbers in this assay, from the lowest: compounds 1, 3 and 2 (each within the scatter of the next).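

In this assay, the ring on the triple-bonded carbon can hold a ring nitrogen without a readable effect: pyridin-3-yl in place of phenyl gives a 1.1-fold higher number from compound 1 to compound 3 (0.03 log units; within the scatter). The entering ring counts 1 hydrogen-bond acceptor and the leaving ring none, yet this difference produces no step beyond the scatter, and the same is true of the methoxy step, a 1.8-fold higher number from compound 1 to compound 2 (0.25 log units; within the scatter). Nothing measured here explains why the ring nitrogen makes so little difference.

From the compounds shown here alone, it remains open whether pyridin-4-yl or cyclohexyl on the triple-bonded carbon would also stay within the scatter of compound 1. Going by these compounds, it is equally open whether an amine or a longer alkyl chain on the pyridin-3-yl ring would do so, or would instead produce a clear step.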